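The source may report more compounds than this note shows. Statements on the series, on what has been measured and on what is new or still open speak of the compounds shown alone.

Series notes. In an assay on isolated protein for inhibition of Calpain-1 catalytic subunit (Homo sapiens), read by fluorescence, with a stated time of 60 min, tested at 1 uM (a lower number here means less inhibition, a higher number more inhibition at the concentration tested (going by the name of the read-out)), compound 1 `CC(C)N/C(=C1/N=CN(C(C)C)C1=O)c1cc2ccccc2[nH]1` gives 57.8%, while compound 2 `O=C1/C(=C(\NC2CCCCC2)c2cc3cccnc3[nH]2)N=CN1C1CCCCC1` gives 4.5%, the lowest of the two numbers recorded and beyond the scatter below compound 1. Compound 3 `O=C1/C(=C(\NC2CCCCC2)c2cc3ccccc3[nH]2)N=CN1C1CCCCC1` is not yet measured; it differs from compound 2 by a group of 9 heavy atoms (8 carbon, 1 nitrogen; one five-membered aromatic ring with 1 hetero atom, one six-membered aromatic ring of carbon only) in place of a group of 9 heavy atoms (7 carbon, 2 nitrogen; one five-membered aromatic ring with 1 hetero atom, one six-membered aromatic ring with 1 hetero atom), on a double-bonded chain carbon bound to an amine nitrogen and a double-bonded ring carbon. Going by the values given here, no pair of measured compounds isolates this change, yet compound 1 carries the same 1H-indol-2-yl group and gives 57.8%, so a rise in this assay beyond the scatter is expected. The expected step of a number 30.5 percentage points higher from compound 2 to compound 3 (beyond the scatter) is sizeable. Compound 3 is estimated at 35%, range 10% to 65%.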

Compound 3, a percentage reported as inhibition, at one concentration (the size of the read-out at that concentration, not a potency): 9%
Beside the measured number, compound 3's estimate is 26 percentage points above it; the whole stated range lies above it.
By their numbers in this assay, from the lowest: compounds 2 and 3 (each within the scatter of the next); then compound 1.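

In this assay, going by these compounds alone, the first matched pair at this position gives a number 4.5 percentage points higher from compound 2 to compound 3 (within the scatter) and so does not separate the 1H-indol-2-yl group from the group it replaces. On a double-bonded chain carbon bound to an amine nitrogen and a double-bonded ring carbon, exchanging these two groups therefore registers no step beyond the scatter with the rest of compound 2 held constant. No available evidence bears on this result.

Compound 1 at 57.8% differs from compound 3 in more than one place, so that value cannot be assigned to any single group. On these data alone, whether a methyl group on the amine nitrogen or a carboxylic acid on the 1H-indol-2-yl group would change the read-out remains open.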